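A ring exchange on the chain carbon: compound 2 to compound 3

The source may hold more compounds than are shown below. What is called first, only, known or untested is meant among the compounds shown, and "the series" means these compounds.

Measured compounds:
compound 1 `CC(C)Sc1nnc(-c2c(CNC3CC3)c3ccccc3n2C)n1-c1ccccc1` — 4.81
compound 2 `CC1CCCN(Cc2c(-c3nnc(SC(C)C)n3-c3ccccc3)n(C)c3ccccc23)C1` — 6.03

Of the compounds shown here, two have been measured in a physicochemical assay for lipophilicity; on this read-out lower numbers stand for lower lipophilicity and higher numbers for higher lipophilicity. Compound 1 `CC(C)Sc1nnc(-c2c(CNC3CC3)c3ccccc3n2C)n1-c1ccccc1` gives 4.81, and compound 2 `CC1CCCN(Cc2c(-c3nnc(SC(C)C)n3-c3ccccc3)n(C)c3ccccc23)C1` gives 6.03. Compound 2 stands highest of the two numbers; its nearest neighbour is compound 1, and the step was a number 1.22 log units higher from compound 1 to compound 2 (beyond the scatter).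

Compound 3 `CC(C)Sc1nnc(-c2c(CNCC3CC3)c3ccccc3n2C)n1-c1ccccc1` has not yet been measured. It differs from compound 2 as follows: (cyclopropylmethyl)amino in place of 3-methylpiperidin-1-yl on a saturated chain carbon bound to an aromatic carbon.

Among the measured compounds shown here, the only measured step that bears on this change is a number 1.22 log units higher from compound 1 to compound 2 (beyond the scatter), in which the same 3-methylpiperidin-1-yl group entered in place of cyclopropylamino at the same place and the number rose by a large margin. The change from compound 2 to compound 3 runs in the opposite direction, removing the 3-methylpiperidin-1-yl group and bringing in (cyclopropylmethyl)amino, which is close in kind to the cyclopropylamino of compound 1 but carries one more carbon. A large fall beyond the scatter is therefore expected in this assay, somewhat smaller than the reverse of a number 1.22 log units higher from compound 1 to compound 2 (beyond the scatter).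

For compound 3 the expected step is a number 0.83 log units lower from compound 2 to compound 3 (beyond the scatter). Compound 3 is therefore estimated at 5.2, within a range of 4.7 to 5.7.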

Compound 3, partition coefficient: 5.24
The estimate for compound 3 lay 0.04 log units below the measured number; measured number inside the range.
By their numbers in this assay, from the lowest: compound 1; then compound 3; then compound 2.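

In this assay, the result gives this position its first step on the amine nitrogen itself: with cyclopropylmethyl in place of cyclopropyl, the number moves a number 0.43 log units higher from compound 1 to compound 3 (beyond the scatter). The step from the ring amine back to an open amine, with (cyclopropylmethyl)amino in place of 3-methylpiperidin-1-yl on the saturated chain carbon, reads a number 0.79 log units lower from compound 2 to compound 3 (beyond the scatter), so compound 3 stands between the other two and both of its steps lie beyond the scatter; a change in the group on the amine nitrogen therefore moves the number here even while the cyclopropyl ring stays in place. Nothing measured on these compounds accounts for either step.

The exchange from compound 2 to compound 3 alters the ring, the heavy-atom count and the hydrogen-bond donor count together, so the compounds shown cannot say which of these the number follows. A piperidin-1-yl group without the methyl, or an open amine with a methyl on its nitrogen beside the cyclopropylmethyl, would bear on that question, and a cyclobutylmethyl group would test whether the rise continues beyond cyclopropylmethyl.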